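From 1-(hydroxymethyl)cyclopropyl to 1-carboxyethyl on the amide

The compounds below may be only part of what the source reports. "The series", "measured", "known", "first", "only" and "open" are said of these compounds alone.

- Compound 1 `CCn1c(C(=O)N[C@H](C)C(=O)OC)ccc1C(CC)(CC)c1ccc(OCS(=O)(=O)c2ccccc2)c(C)c1`: > 50000 nM
- Compound 2 `CCn1c(C(=O)NC2(CO)CC2)ccc1C(CC)(CC)c1ccc(OCS(=O)(=O)c2ccccc2)c(C)c1`: 45400 nM

Among the measured compounds shown here, in a functional assay on BXPC-3 cells (Homo sapiens) for antiproliferative activity, read by MTT assay, with a stated time of 24 h (a higher number here means a weaker inhibitor, a lower number a stronger inhibitor), compound 2 gives 45400 nM, the only true number so far. The value of compound 1, > 50000 nM, is a limit of the assay. Compound 3 `CCn1c(C(=O)N[C@@H](C)C(=O)O)ccc1C(CC)(CC)c1ccc(OCS(=O)(=O)c2ccccc2)c(C)c1` differs from compound 2 by one change: 1-carboxyethyl in place of 1-(hydroxymethyl)cyclopropyl on an amide-type nitrogen. For the measured compounds named here, only one measured step bears on this change, an at least 1.1-fold lower number from compound 1 to compound 2 (0.04 log units; that floor lies within the scatter), and it involves a different pair of groups. With so little to go on, no shift beyond the scatter is expected, and the expected step is a 1.1-fold higher number from compound 2 to compound 3 (0.04 log units; within the scatter). For compound 3 the estimated value is 50000 nM, with an expected range of 22000 nM to 110000 nM.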

Compound 3, half-maximal inhibitory concentration: 20800 nM
Estimate against measurement, compound 3: 2.4-fold (0.38 log units) above; the measured number lies below the stated range.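

In this assay, the group on the amide-type nitrogen now moves the number beyond the scatter, with a 2.2-fold lower number from compound 2 to compound 3 (0.34 log units; beyond the scatter). Exchanging 1-(methoxycarbonyl)ethyl for 1-carboxyethyl also counts, with an at least 2.4-fold lower number from compound 1 to compound 3 (0.38 log units; beyond the scatter). That step is only a floor because the value of compound 1 is a limit of the assay: the limit of > 50000 nM in this assay, at which 1 of the 3 values shown sits.

Compound 2 and compound 3 differ in both the three-membered ring and the carboxyl group, so the contribution of each remains unresolved. Going by these compounds, whether a longer chain ending in a carboxylic acid, or an amine in its place, would lower the number further also stays open.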